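From fluoro to dimethylamino in a growth-inhibition series

The compounds below may be only part of what the source reports. "The series", "measured", "known", "first", "only" and "open" are said of these compounds alone.

Measured so far in a functional assay on HOP-62 cells (Homo sapiens) for inhibition, read by sulforhodamine B assay; on this read-out lower numbers stand for stronger inhibition of growth and higher numbers for weaker inhibition of growth:
Compound 1 `Oc1ccc(-c2ccc(-c3ccc(-c4nc5ccccc5[nH]4)cc3)cc2)cc1` gives 47200 nM
Compound 2 `COc1ccc(-c2ccc(-c3ccc(-c4nc5ccccc5[nH]4)cc3)cc2)cc1OC` gives 4200 nM
Compound 3 `Oc1cccc2[nH]c(-c3ccc(-c4ccc(-c5ccc(F)cc5)cc4)cc3)nc12` gives 8310 nM

Among these three, compound 3 at 8310 nM lies within the scatter of compound 2 and has a lower number than compound 1, by a gap beyond the scatter. The next compound to be tested is compound 4 `CN(C)c1ccc(-c2ccc(-c3ccc(-c4nc5c(O)cccc5[nH]4)cc3)cc2)cc1` which shares the core of compound 3. The change dimethylamino in place of fluoro on an aromatic carbon puts dimethylamino in place of fluoro on an aromatic carbon, so that 4-fluorophenyl becomes 4-(dimethylamino)phenyl.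

Going by the values given here, only one measured step bears on this exchange. The step of an 11-fold lower number from compound 1 to compound 2 (1.05 log units; beyond the scatter) is large and beyond the scatter, and it came when 3,4-dimethoxyphenyl took the place of 4-hydroxyphenyl on an aromatic carbon. That step shows that changing a substituted phenyl group can move the number considerably. However, it involves different groups and a core that differs from that of compound 3, so it gives no size for the present exchange. Neither fluoro nor dimethylamino has been compared directly with another group on this core. Only a small shift towards a lower number is therefore expected in this assay and it may not stand clear of the scatter. The expected step is a 1.4-fold lower number from compound 3 to compound 4 (0.14 log units; within the scatter) and a move in the other direction remains possible. For compound 4 the estimated value is 6000 nM with an expected range from 1800 nM to 20000 nM as its limits.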

Compound 4, concentration for 50% growth inhibition: 8250 nM
Compound 4: middle estimate off by 1.4-fold (0.14 log units), on the low side, and the stated range covers the measured number.
By their numbers in this assay, from the lowest: compounds 2, 4 and 3 (each within the scatter of the next); then compound 1.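

In this assay, going by these compounds alone, putting dimethylamino in place of fluoro on the aromatic carbon para to a large group gives a 1.0-fold lower number from compound 3 to compound 4 (0.00 log units; within the scatter), the first direct comparison of two groups at this place on the shared core, and the two cannot be told apart there. Dimethylamino has more heavy atoms than fluoro and, unlike fluoro, counts as a hydrogen-bond acceptor, yet these differences in make-up come with no separation in the number on this core, whereas the step of an 11-fold lower number from compound 1 to compound 2 (1.05 log units; beyond the scatter) remains the only large one shown and belongs to other groups on a different core. No measurement shown here accounts for the lack of separation between the fluoro and dimethylamino compounds.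

As far as these compounds go, it remains open whether this place is as undiscriminating for other groups, such as a carboxylic acid, a primary amine or a longer alkyl chain, or whether the match between fluoro and dimethylamino is particular to this pair. From the compounds shown here alone, it is also open whether 3,4-dimethoxyphenyl or 4-hydroxyphenyl would separate from these two groups on the core of compound 3, and what the hydroxyl carried on that core contributes.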